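The source may hold more compounds than are shown below. What is called first, only, known or untested is meant among the compounds shown, and "the series" means these compounds.

Measured so far:
Compound 1 `COc1ccc(N(C)c2nc(C)nc3ccccc23)cc1OCCC[Se]C#N`: 799 nM
Compound 2 `COc1ccc(N(C)c2nc(C)nc3ccccc23)cc1C(=O)OCC[Se]C#N`: 2390 nM

In a functional assay on RKO cells (Homo sapiens) for inhibition, read by MTT assay, with a stated time of 48 h (a lower number here means a stronger inhibitor, a higher number a weaker inhibitor), compound 2 has the higher number of the two, at 2390 nM. The next structure is compound 3 `COc1ccc(N(C)c2nc(C)nc3ccccc23)cc1OCCCCCC[Se]C#N`, with this change from compound 2: a group of 10 heavy atoms (7 carbon, 1 nitrogen, 1 oxygen, 1 selenium; no ring) in place of a group of 8 heavy atoms (4 carbon, 1 nitrogen, 2 oxygen, 1 selenium; no ring), on an aromatic carbon. The change sits ortho to a methoxy group, and the group that leaves carries 1 double bond, while the one that enters carries none outside aromatic rings. The group on compound 1 also has no such double bond. Going by the values given here, the only measured step bearing on this is a 3.0-fold higher number from compound 1 to compound 2 (0.48 log units; beyond the scatter), which is modest and beyond the scatter. Among the compounds with values here, a step of similar size toward a lower number is therefore expected, although no measured pair isolates the chain length. The expected move is a 3.7-fold lower number from compound 2 to compound 3 (0.57 log units; beyond the scatter). For compound 3 the estimate is 650 nM, with an expected range of 200 nM to 2000 nM.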

Compound 3, half-maximal inhibitory concentration: 1540 nM
For compound 3 the middle estimate is 2.4-fold (0.37 log units) below the measured one, and the stated range covers the measured number.
By their numbers in this assay, from the lowest: compounds 1, 3 and 2 (each within the scatter of the next, the first and the last beyond it).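

In this assay, the change on the aromatic carbon ortho to a methoxy group, where the group with a carbonyl double bond gives way to a longer chain without one, gives a 1.6-fold lower number from compound 2 to compound 3 (0.19 log units; within the scatter), so the two groups are not separated at this position. Lengthening the chain on the aromatic oxygen gives a 1.9-fold higher number from compound 1 to compound 3 (0.28 log units; within the scatter), so compound 3 lies within the scatter of both earlier compounds and the difference printed for a 3.0-fold higher number from compound 1 to compound 2 (0.48 log units; beyond the scatter) is not reproduced by either single comparison. Nothing available explains these steps.

The shape of any dependence on chain length remains open, since only two chain lengths on the aromatic oxygen are shown. Also open, on these data alone, is whether a longer chain than that of compound 3, or an amine or a carboxylic acid at the chain end in place of the selenium-bearing nitrile, would move the number beyond the scatter.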